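Swapping an Acetyl for an Ethylsulfonyl on Compound 3

This account rests on a few compounds, and the source may have more. Where it says the series, first, only, none or still open, it means among the compounds named here.

Compound 1 `Cn1cncc1CN1CC(N(CC2CCN(C(=O)NC(C)(C)C)CC2)S(=O)(=O)c2ccccn2)Cc2cc(C#N)ccc21` gives 0.6 10^-6 cm/s in an ADME assay on Caco-2 cells (Homo sapiens) for permeability, in the apical to basolateral direction; a lower number here means that the compound crosses the layer more slowly, a higher number that the compound crosses the layer faster.
Compound 2 `Cn1cncc1CN1CC(N(Cc2ccc(S(C)(=O)=O)cc2)S(=O)(=O)c2ccccn2)Cc2cc(C#N)ccc21` gives 0.2 10^-6 cm/s.
Compound 3 `CC(=O)N1CCC(CN(C2Cc3cc(C#N)ccc3N(Cc3cncn3C)C2)S(=O)(=O)c2ccccn2)CC1` gives 0.5 10^-6 cm/s.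

Compound 3 stands second highest of the three. Its step from compound 1 is small: a 1.2-fold lower number from compound 1 to compound 3 (0.08 log units; within the scatter). The step from compound 2 is larger: a 2.5-fold higher number from compound 2 to compound 3 (0.40 log units; beyond the scatter).

Compound 4 `CCS(=O)(=O)N1CCC(CN(C2Cc3cc(C#N)ccc3N(Cc3cncn3C)C2)S(=O)(=O)c2ccccn2)CC1` differs from compound 3 by ethylsulfonyl in place of acetyl on an amine nitrogen in a ring. Among the compounds with values here, no measured step alters only this group, so the two steps above give only a loose guide. The change at this position in the step from compound 1 to compound 3 barely moved the number, and the other step was modest. A step within the scatter, or a slightly lower number, is therefore expected.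

Compound 4 is estimated at 0.4 10^-6 cm/s, between 0.15 10^-6 cm/s and 1 10^-6 cm/s, which is expected to mean a 1.3-fold lower number from compound 3 to compound 4 (0.10 log units; within the scatter).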

Compound 4, apparent permeability: 0.1 10^-6 cm/s
Beside the measured number, compound 4's estimate is 4.0-fold (0.60 log units) above it; measured number below the stated range.
By their numbers in this assay, from the lowest: compounds 4 and 2 (each within the scatter of the next); then compounds 3 and 1 (each within the scatter of the next).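

The amine nitrogen in the ring is not indifferent to what it carries: ethylsulfonyl in place of acetyl gives a 5.0-fold lower number from compound 3 to compound 4 (0.70 log units; beyond the scatter), while the two carbonyl-linked groups stayed within the scatter of each other. Against (tert-butyl)carbamoyl, the same group gives a 6.0-fold lower number from compound 1 to compound 4 (0.78 log units; beyond the scatter). The remaining step, a 2.0-fold lower number from compound 2 to compound 4 (0.30 log units; within the scatter), is small, so the two compounds holding a second sulfonyl group sit together at the low end.

Nothing shown explains these steps. As far as these compounds go, whether the sulfonyl or its ethyl part drives the change stays open, as does the outcome with a free amine or a longer alkyl sulfonyl chain on that nitrogen.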